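A few compounds are considered here, and "the series" means these few. Any claim that something is new, unique, unknown or untested is made for them only; others in the source may bear on it.

Measured in a functional assay on U-937 cells (Homo sapiens) for antiproliferative activity, read by MTT assay, with a stated time of 72 h; a lower number here means a stronger inhibitor, a higher number a weaker inhibitor:
- compound 1 `Cc1ccc(-c2noc(CCCCCCC(=O)Nc3ccccc3N)n2)cc1`: 460 nM
- compound 2 `Nc1ccccc1NC(=O)CCCCCCc1nc(-c2ccc(Cl)cc2)no1`: 4360 nM
- compound 3 `Nc1ccccc1NC(=O)CCCCCCc1nc(-c2cccc([N+](=O)[O-])c2)no1`: 2150 nM

Compound 1 has the lowest number of the three. Its two steps are a 9.5-fold higher number from compound 1 to compound 2 (0.98 log units; beyond the scatter) and a 4.7-fold higher number from compound 1 to compound 3 (0.67 log units; beyond the scatter), and the remaining step is a 2.0-fold lower number from compound 2 to compound 3 (0.31 log units; beyond the scatter).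

Compound 4 `Cc1ccc(-c2noc(CCCCCCC(=O)C(F)(F)F)n2)cc1` keeps the core of compound 1 and alters one group, with trifluoromethyl in place of (2-aminophenyl)amino on a carbonyl carbon.

Among the measured compounds shown here, no measured step touches this place, since all three exchange the substituted phenyl group and leave the (2-aminophenyl)amino group in place. They bear on the change only indirectly, showing modest movement from exchanges of a different group. For the measured compounds named here, no measured compound carries trifluoromethyl, so size and direction remain uncertain. Starting from the lowest number in the set, a modest to moderate move to a higher number in this assay is expected.

The expected change is a 6.5-fold higher number from compound 1 to compound 4 (0.81 log units; beyond the scatter).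

For compound 4 the estimated value is 3000 nM, with an expected range of 600 nM to 15000 nM.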

Compound 4, half-maximal inhibitory concentration: 3730 nM
The estimate for compound 4 lay 1.2-fold (0.09 log units) below the measured number, within the range that was stated.
By their numbers in this assay, from the lowest: compound 1; then compounds 3, 4 and 2 (each within the scatter of the next, the first and the last beyond it).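

In this assay, among the compounds shown here, the exchange on the carbonyl carbon gives an 8.1-fold higher number from compound 1 to compound 4 (0.91 log units; beyond the scatter), the first reading of this place, as the earlier steps all changed the substituted phenyl group. With the 4-methylphenyl group held constant, trifluoromethyl weakens compound 1 but does not abolish activity: compound 4 still gives a measurable 3730 nM without the (2-aminophenyl)amino group and its aromatic ring. No measured information explains this shift.

A single exchange cannot separate the loss of (2-aminophenyl)amino from the entry of trifluoromethyl, and a plain phenylamino group or a hydroxamic acid on the same carbonyl carbon would help to tell them apart. On these data alone, whether the step holds with 4-chlorophenyl or 3-nitrophenyl in place of 4-methylphenyl, or with a shorter chain, remains open.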